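Same Atoms, Rejoined: Compound 2 to Compound 3

The source may report more compounds than this note shows. Statements on the series, on what has been measured and on what is new or still open speak of the compounds shown alone.

In a functional assay on HL-60 cells (Homo sapiens) for inhibition, read by MTT assay, with a stated time of 72 h (on this read-out higher numbers stand for weaker inhibition and lower numbers for stronger inhibition), compound 1 (`CCOc1ccccc1/C=C/C(=O)c1ccc(OCCn2cc(CN3C(=O)/C(=C4\Nc5ccccc5\C4=N/O)c4ccccc43)nn2)cc1O`) gives 980 nM and compound 2 (`CCCOc1ccccc1/C=C/C(=O)c1ccc(OCCn2cc(CN3C(=O)/C(=C4\Nc5ccccc5\C4=N/O)c4ccccc43)nn2)cc1O`) gives 1280 nM, so compound 2 stands within the scatter of compound 1. Compound 3 (`CCCOc1cccc(/C=C/C(=O)c2ccc(OCCn3cc(CN4C(=O)/C(=C5\Nc6ccccc6\C5=N/O)c5ccccc54)nn3)cc2O)c1`) has the same atoms as compound 2, joined differently: a group of 10 heavy atoms (9 carbon, 1 oxygen; one six-membered aromatic ring of carbon only) in place of a group of 10 heavy atoms (9 carbon, 1 oxygen; one six-membered aromatic ring of carbon only), on a double-bonded chain carbon bound to a double-bonded chain carbon. For the measured compounds named here, the only measured step, a 1.3-fold higher number from compound 1 to compound 2 (0.12 log units; within the scatter), bears on this change only indirectly, and no measured pair tests it directly. In this assay, the expected change is a 1.0-fold higher number from compound 2 to compound 3 (0.01 log units; within the scatter), with no shift expected beyond the scatter. For compound 3 the estimated value is 1300 nM, with an expected range from 600 nM to 2900 nM.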

Compound 3, half-maximal inhibitory concentration: 1290 nM
Estimate against measurement, compound 3: 1.0-fold (0.00 log units) above; the range from low to high includes it.
By their numbers in this assay, from the lowest: compounds 1, 2 and 3 (each within the scatter of the next).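

In this assay, for the compounds shown here, rejoining the same atoms as 3-propoxyphenyl on the double-bonded chain carbon gives a 1.0-fold higher number from compound 2 to compound 3 (0.00 log units; within the scatter), so this change of attachment, which the earlier compounds did not test, leaves the number within the scatter. Putting 3-propoxyphenyl in place of 2-ethoxyphenyl gives a 1.3-fold higher number from compound 1 to compound 3 (0.12 log units; within the scatter), also within the scatter. No measurement shown here speaks to what lies behind these results.

The compounds shown leave open whether this place tolerates more different groups. An amine or a carboxylic acid on this aromatic ring, or a chain longer than propoxy, might give a step beyond the scatter.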